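The source may hold more compounds than are shown below. What is called first, only, known or untested is meant among the compounds shown, and "the series" means these compounds.

Working notes on the series.

Compound 1 `ClCc1cccc(Cn2cnc3c(Cl)ncnc32)c1` gives 2450 nM in a functional assay on NCI/ADR-RES cells (Homo sapiens) for cytotoxicity, read by sulforhodamine B assay, with a stated time of 48 h; on this read-out lower numbers stand for stronger inhibition of growth and higher numbers for weaker inhibition of growth. Compound 2 `ClCc1cccc(Cn2cnc3c(Cl)nc(Cl)nc32)c1` carries one further change, (chloro in place of hydrogen on an aromatic carbon), and in this assay compound 2 gives 2390 nM; the step is a 1.0-fold lower number from compound 1 to compound 2 (0.01 log units; within the scatter), so the added chloro leaves the read-out essentially unchanged in this pair.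

Compound 3 `ClCc1ccccc1Cn1cnc2ncnc(Cl)c21` has the same atoms as compound 1 joined differently; the difference between the two cores is not broken down here. In this assay compound 3 gives 2080 nM. The values of compound 1, compound 2 and compound 3 all lie within the usual scatter of one another.

Compound 4 `ClCc1ccccc1Cn1cnc2nc(Cl)nc(Cl)c21` stands to compound 3 as compound 2 stands to compound 1: the change is chloro in place of hydrogen on an aromatic carbon, and its place reads the same word for word as in the pair of compound 1 and compound 2, so it is the same change. For compound 4 a step of a 1.0-fold lower number from compound 3 to compound 4 (0.01 log units; within the scatter) is expected, resting on the step of a 1.0-fold lower number from compound 1 to compound 2 (0.01 log units; within the scatter) seen for the same change. Compound 4 is therefore estimated at 2050 nM in this assay, with an expected range from 1000 nM to 4200 nM.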

Compound 4, concentration for 50% growth inhibition: 2340 nM
Estimate against measurement, compound 4: 1.1-fold (0.06 log units) below, within the range that was stated.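

In this assay, the new step is a 1.1-fold higher number from compound 3 to compound 4 (0.05 log units; within the scatter), so on the core of compound 3, as on the core of compound 1, the added chloro leaves the read-out essentially unchanged. Among the compounds shown here, the two steps for this change can be set side by side, and they do not differ: the same change on two cores in this assay, a 1.0-fold lower number (0.01 log units; within the scatter) from compound 1 to compound 2 and a 1.1-fold higher number (0.05 log units; within the scatter) from compound 3 to compound 4, 1.2-fold (0.06 log units) apart, within the scatter of two such steps This supports carrying the chloro from one of these two cores to the other with no expected shift in growth inhibition, but it rests on only two pairs in one cell line and does not show that the same would hold on any other core or in any other assay.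

From the compounds shown here alone, whether a different group on the carbon between two ring nitrogen atoms, such as an amine or a methoxy group, would move the read-out remains open. Also open, going by these compounds, is whether the flat response to chloro would persist if the chloromethyl group gave way to a hydroxymethyl group or a longer chain.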